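Working notes: the step from compound 1 to compound 4

The compounds below may be only part of what the source reports. "The series", "measured", "known", "first", "only" and "open" are said of these compounds alone.

In a functional assay on SGC-7901 cells (Homo sapiens) for antiproliferative activity, read by MTT assay, with a stated time of 24 h (a lower number here means a stronger inhibitor, a higher number a weaker inhibitor), compound 1 (`O=C(NNc1ccccc1Cl)c1cccc(NS(=O)(=O)c2cnc(O)nc2O)c1`) gives 2270 nM and compound 3 (`O=C(NNC(=O)c1ccccc1Cl)c1ccc(NS(=O)(=O)c2cnc(O)nc2O)cc1`) gives 3240 nM as its number, and the two lie within the scatter of each other. Compound 2 (`Cc1cccc(NNC(=O)c2ccccc2NS(=O)(=O)c2cnc(O)nc2O)c1`) gives > 20000 nM as its result, which is a limit and not a number. Compound 1 therefore stands level with compound 3 among the two true numbers.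

Compound 4 (`Cc1ccccc1C(=O)NNC(=O)c1cccc(NS(=O)(=O)c2cnc(O)nc2O)c1`) is not yet measured. It carries (2-methylphenyl)carbonyl in place of 2-chlorophenyl on an amine nitrogen, and the entering group keeps one six-membered aromatic ring of carbon only. Going by the values given here, no measured step covers this change, so the expectation is loose. The step expected in this assay is (a 1.5-fold higher number from compound 1 to compound 4 (0.19 log units; within the scatter)) slightly toward a weaker inhibitor, with none beyond the scatter. For compound 4 the estimated value is 3500 nM with an expected range from 1200 nM to 12000 nM as a working guess.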

Compound 4, half-maximal inhibitory concentration: > 20000 nM
Compound 4 was reported as a limit (the forecaster's own chance of this, stated with the estimate: 15%); middle value at least 5.7-fold (0.75 log units) away from the limit.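

In this assay, going by these compounds alone, the first measured step is an at least 8.8-fold higher number from compound 1 to compound 4 (0.94 log units; beyond the scatter), and it lies beyond the scatter. Compound 4 gives > 20000 nM, which is a limit and not a number. The position on the amine nitrogen therefore does not accept every group that keeps one six-membered aromatic ring of carbon only, and the true size of the step cannot be read from a result that sits at this shared limit: the limit of > 20000 nM in this assay, at which 2 of the 4 values shown sit.

The entering (2-methylphenyl)carbonyl brings both a carbonyl and a methyl in place of a chlorine, and the compounds shown do not separate these two changes. Going by these compounds, whether a methylene link in place of that carbonyl keeps the number near that of compound 1 also remains open.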